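Acyl variation on the shared core: outlook for compound 4

This account rests on a few compounds, and the source may have more. Where it says the series, first, only, none or still open, it means among the compounds named here.

Measured compounds, all in an assay on Sf9 cells for inhibition of inhibitor of nuclear factor kappa-B kinase subunit epsilon (Homo sapiens), read by ADP-Glo, with a stated time of 60 min; a lower number here means a stronger inhibitor, a higher number a weaker inhibitor:
compound 1 `Cc1[nH]nc(N)c1-c1cccc(Cl)c1` gives 93400 nM in this assay.
compound 2 `CCC(=O)n1nc(C)c(-c2ccc(Cl)c(Cl)c2)c1N` gives > 100000 nM in this assay, which is a limit of the assay and not a number.
compound 3 `Cc1nn(C(=O)C2CCCC2)c(N)c1-c1ccc(Cl)c(Cl)c1` gives > 100000 nM in this assay, likewise a limit and not a number.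

Compound 3 therefore stands only at a limit; of the other values shown, one more is also a limit. Among the compounds with values here, the single step measured in one place, a step that the two limits leave unreadable from compound 2 to compound 3, is left unreadable by the two limits, so no size can be drawn from it; both of its values are covered by the limit of > 100000 nM in this assay, at which 2 of the 3 values shown sit.

Compound 4 `Cc1nn(C(=O)c2ccncc2)c(N)c1-c1ccc(Cl)c(Cl)c1` differs from compound 3 in one place: pyridin-4-yl in place of cyclopentyl on a carbonyl carbon. Within the data shown here, no measured step bears on an aromatic group at that carbonyl carbon, and the one step that touches the same position, from ethyl to cyclopentyl, yields no readable size. The expected step is therefore set at a number no higher from compound 3 to compound 4 (the limit leaves the size open), with no direction beyond the scatter claimed. Compound 4 is expected at 100000 nM in this assay, with a range from 30000 nM to 300000 nM, and most probably the assay will again report only a limit.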

Compound 4, half-maximal inhibitory concentration: > 100000 nM
Compound 4: no number, only a limit; the forecaster's own chance of this, stated with the estimate: 70%; the middle value sits exactly at the limit.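

In this assay compound 4 gives > 100000 nM, which is a limit of the assay and not a number. No step among compound 2, compound 3 and compound 4 can be read: the limit of > 100000 nM in this assay, at which 3 of the 4 values shown sit.

The compounds shown leave open how ethyl, cyclopentyl and pyridin-4-yl on the carbonyl carbon rank against one another.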